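Compound 3 to compound 4: a chlorophenyl swap

The compounds below may be only part of what the source reports. "The series", "measured", "known", "first", "only" and "open" are said of these compounds alone.

compound 1 `Cc1cc(C)cc(NC(=O)NCCNS(=O)(=O)c2ccc(-c3ccccc3Oc3ccc([N+](=O)[O-])c([N+](=O)[O-])c3)s2)c1`: 9100 nM
compound 2 `O=C(NCCNS(=O)(=O)c1ccc(-c2ccccc2Oc2ccc([N+](=O)[O-])c([N+](=O)[O-])c2)s1)Nc1cc(Cl)cc(Cl)c1`: 2300 nM
compound 3 `COc1cccc(NC(=O)NCCNS(=O)(=O)c2ccc(-c3ccccc3Oc3ccc([N+](=O)[O-])c([N+](=O)[O-])c3)s2)c1`: 6700 nM

All three values come from a functional assay on HL-60 cells (Homo sapiens) for inhibition, read by CCK-8 assay, with a stated time of 48 h; on this read-out lower numbers stand for stronger inhibition and higher numbers for weaker inhibition. Compound 3 lies within the scatter of compound 1, shown by a 1.4-fold lower number from compound 1 to compound 3 (0.13 log units; within the scatter). It stands apart from compound 2, shown by a 2.9-fold higher number from compound 2 to compound 3 (0.46 log units; beyond the scatter). The next compound is compound 4 `O=C(NCCNS(=O)(=O)c1ccc(-c2ccccc2Oc2ccc([N+](=O)[O-])c([N+](=O)[O-])c2)s1)Nc1ccc(Cl)cc1`, with 4-chlorophenyl in place of 3-methoxyphenyl on an amide-type nitrogen. The closest evidence is a 4.0-fold lower number from compound 1 to compound 2 (0.60 log units; beyond the scatter), a modest step to the 3,5-dichlorophenyl of compound 2. Among the compounds with values here, no measured compound carries 4-chlorophenyl, so a small move to a lower number in this assay is expected, probably within the scatter. The expected step is a 1.7-fold lower number from compound 3 to compound 4 (0.22 log units; within the scatter). For compound 4 the estimated value is 4000 nM, with an expected range of 1800 nM to 9000 nM.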

Compound 4, half-maximal inhibitory concentration: 8100 nM
Compound 4: middle estimate off by 2.0-fold (0.31 log units), on the low side; the measured number falls inside the stated range.
By their numbers in this assay, from the lowest: compound 2; then compounds 3, 4 and 1 (each within the scatter of the next).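

In this assay, one chlorine is not enough to match the 3,5-dichlorophenyl group on the amide-type nitrogen (a 3.5-fold higher number from compound 2 to compound 4 (0.55 log units; beyond the scatter)), so the presence of chlorine on this phenyl ring does not by itself give the lower number of compound 2. Instead, 4-chlorophenyl reads level with 3-methoxyphenyl (a 1.2-fold higher number from compound 3 to compound 4 (0.08 log units; within the scatter)) and with 3,5-dimethylphenyl (a 1.1-fold lower number from compound 1 to compound 4 (0.05 log units; within the scatter)). Nothing measured here accounts for these steps. Still open, as far as these compounds go, is whether a trifluoromethyl group, a nitrile or a carboxylic acid on this phenyl ring would match compound 2 (2300 nM).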